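Fluoro for tert-butyl: compound 3 to compound 4

A few compounds are considered here, and "the series" means these few. Any claim that something is new, unique, unknown or untested is made for them only; others in the source may bear on it.

In an assay for displacement of a labelled ligand from Sigma non-opioid intracellular receptor 1 (Cavia porcellus), read by scintillation counting, with a stated time of 180 min (a lower number here means a stronger inhibitor, a higher number a weaker inhibitor), compound 1 `OC1CN(CCCCc2ccccc2)CCc2cc(OCc3ccccc3)ccc21` gives 293 nM and compound 2 `OC1CN(CCCOc2ccccc2)CCc2cc(OCc3ccccc3)ccc21` gives 193 nM; the step of a 1.5-fold lower number from compound 1 to compound 2 (0.18 log units; within the scatter) concerns phenoxy in place of benzyl on a saturated chain carbon, three bonds along the chain from an amine nitrogen in a ring. For compound 3 `CC1(C)COC(CCCN2CCc3cc(OCc4ccccc4)ccc3C(O)C2)(c2ccc(C(C)(C)C)cc2)OC1` this assay reports only a limit, > 1000 nM, so compound 3 sits at the limit of > 1000 nM in this assay, at which 1 of the 3 values shown sits, rather than at a number. Compound 4 `CC1(C)COC(CCCN2CCc3cc(OCc4ccccc4)ccc3C(O)C2)(c2ccc(F)cc2)OC1` differs from compound 3 by fluoro in place of tert-butyl on an aromatic carbon. Among the measured compounds shown here, no measured step touches an aromatic substituent on this ring, so none bears directly on this change. Compound 4 is expected at 900 nM, range 300 nM to 3000 nM, in this assay. The step of an at least 1.1-fold lower number from compound 3 to compound 4 (0.04 log units; that floor lies within the scatter) is the expected change, with a real chance that again only a limit is reported.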

Compound 4, inhibition constant: > 1000 nM
Compound 4: only a limit was reported; the forecaster's own chance of this, stated with the estimate: 40%; middle value at least 1.1-fold (0.04 log units) from the limit.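

Compound 3 and compound 4 are each reported in this assay only as a limit, so no step can be read between them. The compounds shown leave open whether fluoro in place of tert-butyl changes the number at all.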